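Adding a nitrile to the carbamoyl-free core

The source may report more compounds than this note shows. Statements on the series, on what has been measured and on what is new or still open speak of the compounds shown alone.

Within the data shown here, compound 3 `C[C@H](Oc1cc2ccccc2nc1N)c1cc(F)ccc1-n1cccn1` is, in a physicochemical assay for lipophilicity, using the shake flask method (a lower number here means a more polar compound, a higher number a more lipophilic compound), the most lipophilic of the three compounds measured so far, giving 4. Among the measured compounds shown here, compound 1 `C[C@H](Oc1cc2cc(C(N)=O)ccc2nc1N)c1cc(F)ccc1-n1cccn1` gives 3 in this assay, and compound 2 `C[C@H](Oc1cc2cc(C(N)=O)ccc2nc1N)c1ncc(F)cc1-n1cccn1` gives 1.9; the gap between compound 2 and compound 3 is the largest among the measured values, but no single-change step connects those two, so only the two numbers themselves can be compared. For the measured compounds named here, the one step that does connect measured compounds is a number 1.00 log units higher from compound 1 to compound 3 (beyond the scatter), a clear rise for taking away the carbamoyl group.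

Compound 4 `C[C@H](Oc1cc2cc(C#N)ccc2nc1N)c1cc(F)ccc1-n1cccn1` is obtained from compound 3 by cyano in place of hydrogen on an aromatic carbon, at the same place where compound 1 carries its carbamoyl group. Going by the values given here, the only relevant measured step therefore points the other way: a group entering at that position lowered the number when it was a carbamoyl. Because the step of a number 1.00 log units higher from compound 1 to compound 3 (beyond the scatter) was a full unit in size, the reverse direction with a different group is expected to give a smaller downward move, estimated as a number 0.50 log units lower from compound 3 to compound 4 (beyond the scatter). Compound 4 is accordingly expected to give 3.5 in this assay, with a likely range from 3 to 4.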

Compound 4, distribution coefficient: 3.8
The estimate for compound 4 lay 0.30 log units below the measured number, within the range that was stated.
By their numbers in this assay, from the lowest: compound 2; then compound 1; then compounds 4 and 3 (each within the scatter of the next).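

In this assay the new step reads a number 0.20 log units lower from compound 3 to compound 4 (within the scatter), so on this read-out a cyano group on this aromatic carbon cannot be told apart from the hydrogen it replaces. Placing cyano where compound 1 carries its carbamoyl group gives a number 0.80 log units higher from compound 1 to compound 4 (beyond the scatter), which shows that the drop seen earlier with carbamoyl does not appear with every group entering at this position, at least not with cyano. The comparison therefore separates the two groups at one shared position on one shared core, but nothing measured here bears on the reason for the difference between them.

Only hydrogen, carbamoyl and cyano are shown at this position, so it remains open whether a group such as an amine, a carboxylic acid or a longer chain would give a number close to that of hydrogen or close to that of carbamoyl. It also remains open whether swapping carbamoyl for cyano would give a step of similar size on the core of compound 2, which differs from the core of compound 1 and has no cyano partner among the compounds shown.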